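Ethyl on the nitrogen of compound 3

The source may report more compounds than this note shows. Statements on the series, on what has been measured and on what is new or still open speak of the compounds shown alone.

Compound 1 `Nc1nc(N)c2cc(N(Cc3ccc(OC(F)(F)F)cc3)Cc3ccc(OC(F)(F)F)cc3)ccc2n1`: 33900 nM
Compound 2 `COc1ccc(CN(Cc2ccc(OC(F)(F)F)cc2)c2ccc3nc(N)nc(N)c3c2)cc1`: 24500 nM
Compound 3 `Nc1nc(N)c2cc(NCc3ccc(OC(F)(F)F)cc3)ccc2n1`: 4750 nM

In a physicochemical assay for inhibition, read by spectrophotometry, with a stated time of 10 min (on this read-out higher numbers stand for weaker inhibition and lower numbers for stronger inhibition), compound 3 gives 4750 nM, the lowest number of the three and beyond the scatter from both others. Compound 4 `CCN(Cc1ccc(OC(F)(F)F)cc1)c1ccc2nc(N)nc(N)c2c1`, not yet measured, differs from it by ethyl in place of hydrogen on a nitrogen on an aromatic ring.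

Two modest steps bear on this nitrogen: a 7.1-fold lower number from compound 1 to compound 3 (0.85 log units; beyond the scatter) and a 5.2-fold lower number from compound 2 to compound 3 (0.71 log units; beyond the scatter). Read in reverse, both show a higher number when the hydrogen is replaced, though by a benzyl group rather than ethyl. Among the measured compounds shown here, no measured compound carries ethyl, so a rise of similar or smaller size is expected. The expected change is a 2.0-fold higher number from compound 3 to compound 4 (0.30 log units; within the scatter). The estimate for compound 4 is 9500 nM, with an expected range of 4000 nM to 25000 nM.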

Compound 4, half-maximal inhibitory concentration: 7360 nM
Estimate against measurement, compound 4: 1.3-fold (0.11 log units) above; the range from low to high includes it.
By their numbers in this assay, from the lowest: compounds 3 and 4 (each within the scatter of the next); then compounds 2 and 1 (each within the scatter of the next).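

In this assay, ethyl in place of hydrogen on this nitrogen gives a 1.5-fold higher number from compound 3 to compound 4 (0.19 log units; within the scatter) and so leaves compound 3 and compound 4 level within the scatter. Filling this nitrogen does not by itself bring the higher numbers of the two larger compounds: methyl in place of 4-methoxyphenyl gives a 3.3-fold lower number from compound 2 to compound 4 (0.52 log units; beyond the scatter) and methyl in place of 4-(trifluoromethoxy)phenyl gives a 4.6-fold lower number from compound 1 to compound 4 (0.66 log units; beyond the scatter) in the same series. No available evidence accounts for this difference.

Still open, as far as these compounds go, is whether a longer chain such as propyl on this nitrogen stays level with compound 3. A chain ending in an amine or a carboxylic acid is equally untested in the compounds shown here.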